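Cytotoxicity notes: aryl amide in place of alkyl urea

The source may hold more compounds than are shown below. What is called first, only, known or untested is meant among the compounds shown, and "the series" means these compounds.

Compound 1 `CCCCNC(=O)Nc1cc2nc(C3CCCCC3)[nH]c2cc1N(CC)CC` sits at a limit in an ADME assay on Vero cells (Chlorocebus sabaeus) for cytotoxicity, read by resazurin assay, with a stated time of 3 days; a lower number here means a stronger inhibitor, a higher number a weaker inhibitor: its value of > 100 ug/mL is an assay ceiling, not a number. Compound 2 `COc1ccc(C(=O)Nc2cc3nc(C4CCCCC4)[nH]c3cc2N(C)C)cc1` likewise reaches only a limit in this assay, giving > 100 ug/mL. Within the data shown here, both values stand at the limit of > 100 ug/mL in this assay, at which 2 of the 2 values shown sit, so no measured step is available in the set. Compound 3 `CCN(CC)c1cc2[nH]c(C3CCCCC3)nc2cc1NC(=O)c1cccc(Br)c1` differs from compound 1 by 3-bromophenyl in place of butylamino on a carbonyl carbon. With both measured values at the ceiling, no step beyond the scatter is expected in this assay, and the step is estimated as a number no higher from compound 1 to compound 3 (the limit leaves the size open). Compound 3 is expected to give about 100 ug/mL, within 40 ug/mL to 200 ug/mL.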

Compound 3, half-maximal inhibitory concentration: > 100 ug/mL
Compound 3: no number, only a limit (the forecaster's own chance of this, stated with the estimate: 75%); the middle value sits exactly at the limit.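

Compound 3 and compound 1 both stand at a limit in this assay, so no step can be read between them: the limit of > 100 ug/mL in this assay, at which 3 of the 3 values shown sit. As far as these compounds go, whether 3-bromophenyl in place of butylamino on a carbonyl carbon changes the read-out at all stays open.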